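Naphthalen-2-yl for Phenyl: Expected Toxicity of Compound 4

The compounds below may be only part of what the source reports. "The series", "measured", "known", "first", "only" and "open" are said of these compounds alone.

Measured so far:
compound 1 `CC(=O)OC[C@H]1O[C@@H](CC(=O)/C=C/c2ccc(NC(=O)Nc3ccccc3)cc2)[C@H](OC(C)=O)[C@@H](OC(C)=O)[C@@H]1OC(C)=O` gives 820000 nM
compound 2 `O=C(/C=C/c1ccc(NC(=O)Nc2ccccc2)cc1)C[C@@H]1O[C@H](CO)[C@@H](O)[C@H](O)[C@H]1O` gives 1130000 nM
compound 3 `CC(=O)OC[C@H]1O[C@@H](CC(=O)/C=C/c2ccc(NC(=O)Nc3ccc4ccccc4c3)cc2)[C@H](OC(C)=O)[C@@H](OC(C)=O)[C@@H]1OC(C)=O` gives 482000 nM

All three were tested in an ADME assay on Vero cells (Chlorocebus sabaeus) for cytotoxicity, read by resazurin assay, with a stated time of 2 days; on this read-out higher numbers stand for lower toxicity in this test and lower numbers for higher toxicity in this test. Compound 1 and compound 2 share the same chain on the urea but differ in their cores; that difference between the two cores is not broken down here, and their two values lie within the scatter of each other. From compound 1 to compound 3 the change is naphthalen-2-yl in place of phenyl on an amide-type nitrogen and the step is a 1.7-fold lower number from compound 1 to compound 3 (0.23 log units; within the scatter). Compound 4 `O=C(/C=C/c1ccc(NC(=O)Nc2ccc3ccccc3c2)cc1)C[C@@H]1O[C@H](CO)[C@@H](O)[C@H](O)[C@H]1O` is not yet measured. It differs from compound 2 by naphthalen-2-yl in place of phenyl on an amide-type nitrogen, the same change at the same place. Because the earlier step of a 1.7-fold lower number from compound 1 to compound 3 (0.23 log units; within the scatter) was small, a step of similar size, a 1.7-fold lower number from compound 2 to compound 4 (0.23 log units; within the scatter), is expected from compound 2 to compound 4. Compound 4 is thus estimated at 660000 nM, likely between 300000 nM and 1400000 nM.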

Compound 4, half-maximal cytotoxic concentration: 1020000 nM
For compound 4 the middle estimate is 1.5-fold (0.19 log units) below the measured one; measured number inside the range.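

In this assay naphthalen-2-yl in place of phenyl on an amide-type nitrogen gives a 1.1-fold lower number from compound 2 to compound 4 (0.04 log units; within the scatter) on the core of compound 2. Set beside the earlier step, the change shows no detectable difference between the two cores: the same change on two cores in this assay, a 1.7-fold lower number (0.23 log units; within the scatter) from compound 1 to compound 3 and a 1.1-fold lower number (0.04 log units; within the scatter) from compound 2 to compound 4, 1.5-fold (0.19 log units) apart, within the scatter of two such steps. This suggests that the swap carries across these two cores with little effect on the number, but since both steps lie within the scatter, it does not show that the swap has any real effect, and two cores do not make a rule for the whole series.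

The compounds shown leave open how other groups on that nitrogen would behave, such as a simple alkyl chain, an amine-bearing chain or a carboxylic acid-bearing ring. They also leave open whether the same small step would appear on any other core.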